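This account rests on a few compounds, and the source may have more. Where it says the series, first, only, none or still open, it means among the compounds named here.

Measured so far in a functional assay on A-431 cells (Homo sapiens) for cytotoxicity; on this read-out lower numbers stand for an effect already at smaller amounts and higher numbers for an effect only at larger amounts of compound:
- compound 1 `COC1=C(C)C(=O)/C(=C(O)/C=C/c2ccc(O)cc2)C(=O)C1(C)C` gives 14.9 ug/mL
- compound 2 `COC1=C(C)C(=O)/C(=C(O)/C=C/c2ccc(F)cc2)C(=O)C1(C)C` gives 4.1 ug/mL
- compound 3 `COC1=C(C)C(=O)/C(=C(O)/C=C/c2cccc3ccccc23)C(=O)C1(C)C` gives 4.1 ug/mL

Compound 2 stands level with compound 3 at the digits shown, and together they hold the lowest number of the three. Compound 1 has the highest number, and its gap to compound 2 lies beyond the scatter.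

The next step leads to compound 4 `COC1=C(C)C(=O)/C(=C(O)/C=C/c2cccs2)C(=O)C1(C)C` and is described by thiophen-2-yl in place of 4-fluorophenyl on a double-bonded chain carbon bound to a double-bonded chain carbon. In words, thiophen-2-yl comes in place of 4-fluorophenyl on a double-bonded chain carbon bound to a double-bonded chain carbon.

Going by the values given here, no measured compound carries this five-membered ring, so the evidence is indirect. Among the compounds with values here, the one measured single change is a 3.6-fold lower number from compound 1 to compound 2 (0.56 log units; beyond the scatter), a modest step that alters a substituent on the aromatic ring and leaves the ring itself in place. Compound 3 carries a different aromatic group on the same chain carbon and reads 4.1 ug/mL, the same number as compound 2. That single exchange of aromatic groups gives no change in this assay, so no large step is expected here. The estimated change is a 1.3-fold higher number from compound 2 to compound 4 (0.13 log units; within the scatter), which would stay within the scatter. The estimate for compound 4 is 5.5 ug/mL, expected to lie between 2.5 ug/mL and 12 ug/mL.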

Compound 4, concentration for half-maximal effect: 10.8 ug/mL
For compound 4 the middle estimate is 2.0-fold (0.29 log units) below the measured one; measured number inside the range.
By their numbers in this assay, from the lowest: compounds 2 and 3 (each within the scatter of the next); then compounds 4 and 1 (each within the scatter of the next).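

In this assay, the group on the double-bonded chain carbon bound to a double-bonded chain carbon can shift the read-out: thiophen-2-yl in place of 4-fluorophenyl gives a 2.6-fold higher number from compound 2 to compound 4 (0.42 log units; beyond the scatter). Compound 2 and compound 3 print the same number with different aromatic groups at this place, so the level seen there does not carry over to every aromatic group. Thiophen-2-yl in place of 4-hydroxyphenyl gives a 1.4-fold lower number from compound 1 to compound 4 (0.14 log units; within the scatter), which leaves compound 1 and compound 4 unseparated, so among the four compounds the aromatic groups fall into two sets: 4-fluorophenyl with the group of compound 3, and 4-hydroxyphenyl with thiophen-2-yl.

Going by these compounds, it remains open whether a furan-2-yl, pyridin-3-yl, 4-chlorophenyl or 4-aminophenyl group at this place would read with compound 2 and compound 3 or with compound 1 and compound 4 in this assay. No supporting measurement is available to explain the separation between thiophen-2-yl and 4-fluorophenyl at this place.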